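This account rests on a few compounds, and the source may have more. Where it says the series, first, only, none or still open, it means among the compounds named here.

Compound 1 `c1ccc(Oc2ccc(Cc3nc4ccccc4[nH]3)cc2)cc1`: 4200 nM
Compound 2 `O=[N+]([O-])c1ccc2[nH]c(Cc3ccc(Oc4ccccc4)cc3)nc2c1`: 1200 nM
Compound 3 `Oc1ccc2[nH]c(CN3CCC(Cc4ccccc4F)CC3)nc2c1`: 730 nM

All three numbers come from an assay on membranes from brain for binding affinity to Adrenergic receptor alpha-1 (Rattus norvegicus); a lower number here means a stronger inhibitor, a higher number a weaker inhibitor. Compound 3 and compound 2 lie within the usual scatter of each other, so no order between them can be read from these values, while compound 1 stands beyond that scatter with a clearly higher number. For the measured compounds named here, the only step between two compounds that differ in a single place is a 3.5-fold lower number from compound 1 to compound 2 (0.54 log units; beyond the scatter). That step concerns a substituent on an aromatic carbon of the shared core, not the part of the molecule that changes here, so it offers no direct guide.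

Compound 4 `Cc1ccc(CC2CCN(Cc3nc4cc(O)ccc4[nH]3)CC2)cc1` is compound 3 with one change: 4-methylphenyl in place of 2-fluorophenyl on a saturated chain carbon bound to a saturated ring carbon. Going by the values given here, no measured pair shows this exchange, so nothing in the data argues for a move in either direction. The working assumption is therefore that compound 4 stays close to compound 3, whose number is 730 nM. The expected step of no change at the digits printed from compound 3 to compound 4 (within the scatter) is thus within the scatter. For compound 4 the estimate is 730 nM, with a range from 250 nM to 2200 nM, and the measurement will show whether this holds.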

Compound 4, half-maximal inhibitory concentration: 830 nM
Estimate against measurement, compound 4: 1.1-fold (0.06 log units) below; low and high end bracket the measured number.
By their numbers in this assay, from the lowest: compounds 3, 4 and 2 (each within the scatter of the next); then compound 1.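

In this assay, for the compounds shown here, putting 4-methylphenyl in place of 2-fluorophenyl on a saturated chain carbon bound to a saturated ring carbon gives a 1.1-fold higher number from compound 3 to compound 4 (0.06 log units; within the scatter) and so provides the first measured pair that varies this part of the molecule. The earlier step concerned a substituent on an aromatic carbon of the shared core, whereas this pair shows that the benzyl end can go from 2-fluorobenzyl to 4-methylbenzyl with no readable difference in the number. No measured property of these two groups accompanies the result, so the data give no explanation for it.

The exchange alters both the substituent and its place in the name, so this single pair cannot show what a methyl group would do as 2-methylphenyl or a fluorine as 4-fluorophenyl, or whether the two alterations happen to offset each other. It also leaves open whether this end of the molecule would tolerate a very different group, such as a carboxylic acid or an amine on the phenyl ring, or a longer chain in place of the benzyl link.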